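The source may hold more compounds than are shown below. What is called first, only, known or untested is meant among the compounds shown, and "the series" means these compounds.

Measured so far:
- Compound 1, `CCn1c(=O)/c(=C2\Sc3ccccc3N2C)s/c1=C\c1ccncc1Nc1ccccc1C`: in a functional assay on CWR22R cells (Homo sapiens) for inhibition (a higher number here means a weaker inhibitor, a lower number a stronger inhibitor), compound 1 gives 470 nM.
- Compound 2, `CCn1c(=O)/c(=C2\Sc3ccc(C)cc3N2C)s/c1=C\c1ccncc1Nc1ccccc1F`: in this assay compound 2 gives 150 nM.
- Compound 3, `c1ccc(Nc2cccc(-c3nc4ccccc4s3)c2)nc1`: in this assay compound 3 gives 13000 nM.

Compound 2 has the lowest number of the three; compound 1 lies closest to it, and compound 3, which is built on a different core, lies furthest away, and both gaps are beyond the usual scatter. Compound 4, `CCn1c(=O)/c(=C2\Sc3ccc(C)cc3N2C)s/c1=C\c1ccncc1Nc1ccccc1C`, has not yet been measured in this assay. It differs from compound 2 in a single place: methyl in place of fluoro on an aromatic carbon. Among the measured compounds shown here, no measured pair shows this exact change on this core, so the size of the step cannot be read from the data. Compound 1 carries the same (2-methylphenyl)amino group and gives a higher number than compound 2, but it also differs from compound 2 elsewhere. The expectation is a small rise, possibly within the scatter: compound 4 is estimated at 250 nM, with a range of 100 nM to 600 nM, a step of a 1.7-fold higher number from compound 2 to compound 4 (0.22 log units; within the scatter).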

Compound 4, half-maximal inhibitory concentration: 480 nM
The estimate for compound 4 lay 1.9-fold (0.28 log units) below the measured number; the measured number falls inside the stated range.
By their numbers in this assay, from the lowest: compound 2; then compounds 1 and 4 (each within the scatter of the next); then compound 3.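

On the shared core, the change from 2-fluorophenyl to 2-methylphenyl is not neutral: in this assay it gives a clear step (a 3.2-fold higher number from compound 2 to compound 4 (0.51 log units; beyond the scatter)). Methyl in place of hydrogen on the other aromatic ring gives a step within the scatter (a 1.0-fold higher number from compound 1 to compound 4 (0.01 log units; within the scatter)), so the gap between compound 1 and compound 2 goes with the fluoro-to-methyl change. Nothing measured here explains why this change has that effect.

The compounds shown leave open how chloro, methoxy or an amine would read at this place, and whether a plain phenyl would stand closer to the fluoro or the methyl compound.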